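The compounds below may be only part of what the source reports. "The series", "measured", "known", "first", "only" and "open" are said of these compounds alone.

Among the compounds with values here, compound 2 `CCn1c(C(=O)N[C@@H](CO)CCO)ccc1C(CC)(CC)c1ccc(OCS(=O)(=O)c2ccccc2)c(C)c1` gives 14100 nM in a functional assay on PC-3 cells (Homo sapiens) for antiproliferative activity, read by MTT assay, with a stated time of 24 h (a higher number here means a weaker inhibitor, a lower number a stronger inhibitor), the upper of the two numbers so far, though its only neighbour sits within the scatter: compound 1 `CCN(CC)CCNC(=O)c1ccc(C(CC)(CC)c2ccc(OCS(=O)(=O)c3ccccc3)c(C)c2)n1CC` in this assay gives 7130 nM, with a 2.0-fold higher number from compound 1 to compound 2 (0.30 log units; within the scatter). Compound 3 `CCn1c(C(=O)N[C@@H](CCC(=O)O)C(=O)O)ccc1C(CC)(CC)c1ccc(OCS(=O)(=O)c2ccccc2)c(C)c1` differs from compound 2 by 1,3-dicarboxypropyl in place of 3-hydroxy-1-(hydroxymethyl)propyl on an amide-type nitrogen. Within the data shown here, the only measured step on this amide-type nitrogen, a 2.0-fold higher number from compound 1 to compound 2 (0.30 log units; within the scatter), stayed within the scatter, so no shift beyond the scatter is expected in this assay for this change either. Compound 3 is therefore estimated at 14000 nM, within 5000 nM to 40000 nM, meaning an expected 1.0-fold lower number from compound 2 to compound 3 (0.00 log units; within the scatter).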

Compound 3, half-maximal inhibitory concentration: > 50000 nM
Compound 3 was reported as a limit (the forecaster's own chance of this, stated with the estimate: 15%); middle value at least 3.5-fold (0.55 log units) away from the limit.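

With 1,3-dicarboxypropyl on this amide-type nitrogen, an at least 3.5-fold higher number from compound 2 to compound 3 (0.54 log units; beyond the scatter) in this assay shows that this position does respond beyond the scatter, which the earlier pair did not show. Against 2-(diethylamino)ethyl, the same group gives an at least 7.0-fold higher number from compound 1 to compound 3 (0.84 log units; beyond the scatter) in the same direction. Compound 3 is reported only as a limit, and the full size of both steps stays unknown: the limit of > 50000 nM in this assay, at which 1 of the 3 values shown sits.

The compounds shown leave open whether methyl esters in place of the two carboxylic acids would bring the number back within the scatter of compound 2. They also leave open whether a single carboxylic acid on a shorter chain would behave like 1,3-dicarboxypropyl.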